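Methoxy in Place of Fluoro: What to Expect for Compound 4

The source may report more compounds than this note shows. Statements on the series, on what has been measured and on what is new or still open speak of the compounds shown alone.

Measured so far in an assay on isolated protein for inhibition of Dihydrofolate reductase (Homo sapiens), read by spectrophotometry; on this read-out higher numbers stand for weaker inhibition and lower numbers for stronger inhibition:
Compound 1, `COc1ccc(N(C)Cc2nc3cc(C(F)(F)F)ccc3nc2-c2ccccc2)cc1`, gives 3000 nM.
Compound 2, `CCN(Cc1nc2cc(C(F)(F)F)ccc2nc1-c1ccccc1)c1ccc(C)cc1`, gives 4000 nM.
Compound 3, `CCN(Cc1nc2cc(C(F)(F)F)ccc2nc1-c1ccccc1)c1ccc(F)cc1`, gives 3000 nM.

Compound 3 stands level with compound 1, and the remaining measured step is a 1.3-fold lower number from compound 2 to compound 3 (0.12 log units; within the scatter), so the three measured numbers sit together within the usual scatter of this assay. Compound 4, `CCN(Cc1nc2cc(C(F)(F)F)ccc2nc1-c1ccccc1)c1ccc(OC)cc1`, differs from compound 3 by one change: methoxy in place of fluoro on an aromatic carbon.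

Within the data shown here, two measured steps bear on this. Going from compound 1 to compound 2 swaps the methoxyphenyl group for a methylphenyl group (along with the methyl-to-ethyl change) and gives a 1.3-fold higher number from compound 1 to compound 2 (0.12 log units; within the scatter). Going from compound 1 to compound 3 swaps the same methoxyphenyl for a fluorophenyl and gives no change at the digits printed from compound 1 to compound 3 (within the scatter). In both cases the group para to the large group was changed and the number barely moved. Compound 4 simply combines the ethyl of compound 3 with the methoxy of compound 1, so no step beyond the scatter is expected in this assay. The expected step from compound 3 to compound 4 is therefore no change at the digits printed from compound 3 to compound 4 (within the scatter). Compound 4 is estimated at 3000 nM, with a likely range from 1500 nM to 6000 nM.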

Compound 4, inhibition constant: 7000 nM
Compound 4: middle estimate off by 2.3-fold (0.37 log units), on the low side; measured number above the stated range.
By their numbers in this assay, from the lowest: compounds 1, 3, 2 and 4 (each within the scatter of the next, the first and the last beyond it).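

In this assay, among these compounds, there is a 2.3-fold higher number from compound 3 to compound 4 (0.37 log units; beyond the scatter) for methoxy in place of fluoro on an aromatic carbon, para to a large group, so the group at this place can shift the number beyond the usual scatter, which no earlier step had done. Methoxy and methyl at the same place cannot be told apart, however, since a 1.8-fold higher number from compound 2 to compound 4 (0.24 log units; within the scatter) stays within the scatter, so the clear difference here is between methoxy and fluoro alone. With the methoxy held fixed, there is also a 2.3-fold higher number from compound 1 to compound 4 (0.37 log units; beyond the scatter) for methyl in place of hydrogen on a saturated chain carbon bound to a nitrogen on an aromatic ring, which shows that this second place can also move the number beyond the scatter.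

Going by these compounds, it remains open how a hydroxyl, an amine or a carboxylic acid at the ring position would behave, and whether a propyl chain on the nitrogen would continue the shift seen with the ethyl. The data shown offer no independent evidence to explain why either change has this effect.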